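Compound 3 to compound 4: replacing the 2,6-dibromophenyl group

The compounds below may be only part of what the source reports. "The series", "measured", "known", "first", "only" and "open" are said of these compounds alone.

In an ADME assay on microsomes from liver (Rattus norvegicus) for metabolic stability, read by LC-MS, using NADPH, at 37 degrees C (a lower number here means that the compound disappears faster, a higher number that the compound lasts longer), compound 1 `Cc1cc(C)c(-c2nc(CN3CCC(C(=O)NCCCN4C[C@H](C)C[C@H](C)C4)CC3)c(C)o2)c(C)c1` reports only a limit, > 0.5 h. Compound 2 `Cc1oc(-c2c(Cl)cccc2Cl)nc1CN1CCC(C(=O)NCCCN2C[C@H](C)C[C@H](C)C2)CC1` gives 0.0483 h and compound 3 `Cc1oc(-c2c(Br)cccc2Br)nc1CN1CCC(C(=O)NCCCN2C[C@H](C)C[C@H](C)C2)CC1` gives 0.035 h. These two values lie within the scatter of each other, with a 1.4-fold lower number from compound 2 to compound 3 (0.14 log units; within the scatter). Compound 3 therefore stands with compound 2, well apart from compound 1, and the large steps are an at least 10-fold lower number from compound 1 to compound 2 (1.01 log units; beyond the scatter) and an at least 14-fold lower number from compound 1 to compound 3 (1.15 log units; beyond the scatter).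

Compound 4 `Cc1oc(-c2c(Cl)cccc2C(F)(F)F)nc1CN1CCC(C(=O)NCCCN2C[C@H](C)C[C@H](C)C2)CC1` differs from compound 3 in one place: 2-chloro-6-(trifluoromethyl)phenyl in place of 2,6-dibromophenyl on an aromatic carbon. It carries no 2,4,6-trimethylphenyl, the group of compound 1, so the two large steps are a weak guide here. The closest measured exchange is a 1.4-fold lower number from compound 2 to compound 3 (0.14 log units; within the scatter), which stayed within the scatter. On that basis, no change beyond the scatter is expected in this assay, and the expected step is a 1.3-fold higher number from compound 3 to compound 4 (0.11 log units; within the scatter). For compound 4 the estimated half-life is 0.045 h, with an expected range of 0.02 h to 0.11 h.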

Compound 4, half-life: 0.03 h
Estimate against measurement, compound 4: 1.5-fold (0.18 log units) above; low and high end bracket the measured number.
By their numbers in this assay, from the lowest: compounds 4, 3 and 2 (each within the scatter of the next). At a limit, above all of these: compound 1.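

In this assay, 2-chloro-6-(trifluoromethyl)phenyl in place of 2,6-dibromophenyl gives a 1.2-fold lower number from compound 3 to compound 4 (0.07 log units; within the scatter), and trifluoromethyl in place of chloro gives a 1.6-fold lower number from compound 2 to compound 4 (0.21 log units; within the scatter), so compound 2, compound 3 and compound 4 now form a group of three within the scatter, where earlier only a chloro and bromo pair could be compared. With an at least 16-fold lower number from compound 1 to compound 4 (1.22 log units; beyond the scatter), a third exchange from 2,4,6-trimethylphenyl is also large, and among the groups shown at this position only that group stands apart. The number for compound 1 is a limit, so this step has a limit at one end: the limit of > 0.5 h in this assay, at which 1 of the 4 values shown sits.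

The compounds shown leave open how far the half-life of compound 1 extends past its limit, and which methyl group of 2,4,6-trimethylphenyl carries the step. Going by these compounds, whether a phenyl group bearing a methoxy or an amine falls with the halogen-bearing groups or with 2,4,6-trimethylphenyl also stays open.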